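The compounds below may be only part of what the source reports. "The series", "measured", "known", "first", "only" and "open" are said of these compounds alone.

Measured in a functional assay on MCF7 cells (Homo sapiens) for cytotoxicity, read by MTT assay, with a stated time of 96 h; on this read-out higher numbers stand for weaker inhibition and lower numbers for stronger inhibition:
- compound 1 `COc1cc(C(=O)c2cn(-c3ccccc3)cc2-c2ccc(Cl)cc2)cc(OC)c1OC`: 290 nM
- compound 2 `COc1cc(C(=O)c2cn(-c3ccccc3)cc2-c2cccc([N+](=O)[O-])c2)cc(OC)c1OC`: 50 nM

Of these two, compound 2 has the lower number, 50 nM. Compound 3 `COc1cc(C(=O)c2cn(-c3ccccc3)cc2-c2ccc([N+](=O)[O-])cc2)cc(OC)c1OC` carries 4-nitrophenyl in place of 3-nitrophenyl on an aromatic carbon. Among the compounds with values here, only one measured step bears on this: a 5.8-fold lower number from compound 1 to compound 2 (0.76 log units; beyond the scatter). That step changed the group as well as its position, so it offers only a loose guide. Still, the 4-chlorophenyl compound 1 gives 290 nM, so a modest move towards a higher number is expected in this assay. The expected change is a 2.4-fold higher number from compound 2 to compound 3 (0.38 log units; beyond the scatter). For compound 3 the estimated value is 120 nM, with a range of 35 nM to 400 nM.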

Compound 3, half-maximal inhibitory concentration: 590 nM
Compound 3: middle estimate off by 4.9-fold (0.69 log units), on the low side, outside the stated range (above it).
By their numbers in this assay, from the lowest: compound 2; then compound 1; then compound 3.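

In this assay, the two nitro compounds have the same atoms, yet 4-nitrophenyl in place of 3-nitrophenyl gives a large change (a 12-fold higher number from compound 2 to compound 3 (1.07 log units; beyond the scatter)), so where the nitro group sits on this ring matters greatly. Nitro in place of chloro gives a modest change in the opposite direction from the first step (a 2.0-fold higher number from compound 1 to compound 3 (0.31 log units; beyond the scatter)), so a nitro group does not lower the number wherever it sits. Nothing here explains why this placement matters. Going by these compounds, whether an amine or a carboxylic acid in place of the nitro group would depend as strongly on placement remains open.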